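From Methoxy to Nitro: an Expected Rise in Toxicity

This account rests on a few compounds, and the source may have more. Where it says the series, first, only, none or still open, it means among the compounds named here.

Three close relatives of one shared core have been tested in a toxicity assay on the whole organism with Rattus norvegicus as the target, at a dose of 400 mg/kg by the oral route; a higher number here means a stronger effect of the compound at the dose given, a lower number a weaker effect. Compound 1 `COc1ccc(OCC2=NCCO2)cc1` gives 15% and stands lowest of the three. Compound 2 `Cc1ccccc1OCC1=NCCO1` gives 40%, a step beyond the scatter above compound 1, and compound 3 `Clc1ccccc1OCC1=NCCO1` gives 80%, the highest number and the furthest from compound 1.

The step from compound 1 to the unmeasured compound 4 `O=[N+]([O-])c1ccc(OCC2=NCCO2)cc1` exchanges one group on the aromatic ring: nitro in place of methoxy on an aromatic carbon. For the measured compounds named here, no measured pair shows this exact exchange. Going by the values given here, the only single-point step among the measured compounds, a number 40 percentage points higher from compound 2 to compound 3 (beyond the scatter), shows that swapping one substituent on the ring can shift this assay by a large amount, and in that case the number moved upward. On this slender evidence the exchange in compound 4 is expected to raise the number rather than lower it, with the size quite uncertain. Compound 4 is estimated at 40%, within a range of 15% to 75%, which corresponds to an expected step of a number 25 percentage points higher from compound 1 to compound 4 (beyond the scatter).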

Compound 4, a percentage reported as activity, at one dose (the size of the read-out at that dose, not a potency): 20%
Compound 4: the middle estimate sits 20 percentage points above what was measured; measured number inside the range.
By their numbers in this assay, from the lowest: compounds 1 and 4 (each within the scatter of the next); then compound 2; then compound 3.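

In this assay, putting nitro in place of methoxy on an aromatic carbon, para to a group of 7 heavy atoms, gives a number 5 percentage points higher from compound 1 to compound 4 (within the scatter). A change of substituent on this ring therefore need not shift the read-out: the large a number 40 percentage points higher from compound 2 to compound 3 (beyond the scatter) belongs to its own exchange of groups and does not carry over to this one, even though the entering nitro differs from the leaving methoxy in its heavy atoms and its hydrogen-bond acceptors. Nothing available here explains why this exchange leaves the read-out within the scatter.

From the compounds shown here alone, whether an amine or a carboxylic acid on this same aromatic carbon would give a number beyond the scatter of compound 1 remains open. Also open, going by these compounds, is whether methoxy and nitro would still match each other on a different carbon of the ring.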